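Isobutyl versus propyl esters at the adenosine A2b receptor

The source may report more compounds than this note shows. Statements on the series, on what has been measured and on what is new or still open speak of the compounds shown alone.

Compound 1 `CCCOC(=O)C1=C(C)NC(=S)NC1c1ccco1` gives 46% in an assay on membranes from HEK293 cells for displacement of a labelled ligand from adenosine receptor A2b (Homo sapiens), read by scintillation counting, with a stated time of 30 min, tested at 1 uM; on this read-out higher numbers stand for more inhibition at the one concentration tested (going by the name of the read-out) and lower numbers for less inhibition.
Compound 2 `CC1=C(C(=O)OCC(C)C)C(c2ccco2)NC(=S)N1` gives 18% in this assay.
Compound 3 `CCCOC(=O)C1=C(C)N(C)C(=O)NC1c1ccco1` gives 23% in this assay.

From compound 1 to compound 2 the change is methyl in place of hydrogen on a saturated chain carbon bound to two saturated chain carbons, and it gave a number 28 percentage points lower from compound 1 to compound 2 (beyond the scatter). Compound 4 `CC1=C(C(=O)OCC(C)C)C(c2ccco2)NC(=O)N1C` carries the same change relative to compound 3, (methyl in place of hydrogen on a saturated chain carbon bound to two saturated chain carbons), at the same place. The difference between the core of compound 1 and the core of compound 3 is not broken down here. Since compound 3 already sits at 23%, the room for a fall of the earlier size is limited; a smaller drop is expected from compound 3 to compound 4, a number 15 percentage points lower from compound 3 to compound 4 (beyond the scatter), because the earlier step of a number 28 percentage points lower from compound 1 to compound 2 (beyond the scatter) points downward. Compound 4 is therefore estimated at 8% in this assay, between 0% and 22%.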

Compound 4, a percentage reported as inhibition, at one concentration (the size of the read-out at that concentration, not a potency): 4%
For compound 4 the middle estimate is 4 percentage points above the measured one, and the stated range covers the measured number.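

Replacing propyl with isobutyl on the core of compound 3 gave a number 19 percentage points lower from compound 3 to compound 4 (beyond the scatter) in this assay. The change therefore carried over between the two cores in direction and, within the scatter, in size: the same change on two cores in this assay, a number 28 percentage points lower (beyond the scatter) from compound 1 to compound 2 and a number 19 percentage points lower (beyond the scatter) from compound 3 to compound 4, 9 percentage points apart, within the scatter of two such steps

Going by these compounds alone, this rests on only two pairs, so it does not show that the change would behave the same way on any other core, and it does not break down the difference between the two cores. The compounds shown leave open how a longer chain or a benzyl group in place of propyl or isobutyl would read in this assay. They also leave open whether an amine or a carboxylic acid could be carried there at all.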